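Furan-2-yl in Place of Methanesulfonamido: Expected Cell Toxicity

The source may hold more compounds than are shown below. What is called first, only, known or untested is meant among the compounds shown, and "the series" means these compounds.

Compound 1, `O=C(Nc1cccc(-c2ccco2)c1)C1CCCN(C(=O)c2cc(C(F)(F)F)cc(C(F)(F)F)c2)C1`: 0%
Compound 2, `CS(=O)(=O)Nc1cccc(C(=O)N2CCCC(C(=O)Nc3ccc(Cl)cc3)C2)c1`: 3%

Of the compounds shown here, two have been measured in an ADME assay on PC-3 cells (Homo sapiens) for cytotoxicity, read by WST assay, tested at 100 uM (on this read-out lower numbers stand for less inhibition and higher numbers for more inhibition at the one concentration tested (going by the name of the read-out)), so far, and both barely register: compound 1 gives 0% and compound 2 gives 3%. Compound 2 carries the higher of the two numbers, but the gap to compound 1 lies within the scatter, so the two cannot be told apart.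

Compound 3, `O=C(Nc1ccc(Cl)cc1)C1CCCN(C(=O)c2cccc(-c3ccco3)c2)C1`, shares the core of compound 2 and differs in one place, on an aromatic carbon of a six-membered aromatic ring of carbon only, meta to a large group: furan-2-yl in place of methanesulfonamido on an aromatic carbon.

Among the compounds with values here, no measured pair shows the size of this change. Since compound 1 and compound 2 both sit near zero, a step of no size beyond the scatter is expected for compound 3, estimated as no change at the digits printed from compound 2 to compound 3 (within the scatter). Compound 3 is thus expected to give 3% in this assay, within 0% to 15%.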

Compound 3, a percentage reported as inhibition, at one concentration (the size of the read-out at that concentration, not a potency): 0%
The estimate for compound 3 lay 3 percentage points above the measured number; the measured number falls inside the stated range.
By their numbers in this assay, from the lowest: compounds 1, 3 and 2 (each within the scatter of the next).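

In this assay, within the data shown here, the only measured step at this position is a number 3 percentage points lower from compound 2 to compound 3 (within the scatter), for furan-2-yl in place of methanesulfonamido on an aromatic carbon. Exchanging a group with no ring for a five-membered aromatic ring of the same heavy-atom count therefore gives two compounds that cannot be told apart here, even though the hydrogen-bond donor of methanesulfonamido is absent from furan-2-yl. No measurement shown accounts for how close both compounds stay to zero.

As far as these compounds go, whether an amine or a carboxylic acid on this aromatic carbon would give a number beyond the scatter remains open. From the compounds shown here alone, how these compounds behave at any concentration other than the one tested also remains open.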